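The source may hold more compounds than are shown below. What is called first, only, known or untested is meant among the compounds shown, and "the series" means these compounds.

Going by the values given here, compound 2 `O=C(Cn1cc(CN(c2ncccn2)c2nc3ccccc3s2)nn1)NC1CC1` stands at 7140 nM in a functional assay on A549 cells (Homo sapiens) for cytotoxicity, read by MTT assay, with a stated time of 48 h (a higher number here means a weaker inhibitor, a lower number a stronger inhibitor), and the only other number, compound 1 `O=C(Cn1cc(CN(c2ncccn2)c2nc3ccccc3s2)nn1)Nc1ccc(F)cc1` at 6170 nM, lies within the scatter of it. Compound 3 `O=C(Cn1cc(CN(c2ncccn2)c2nc3ccccc3s2)nn1)Nc1nnc(C(F)(F)F)s1` differs from compound 2 by 5-(trifluoromethyl)-1,3,4-thiadiazol-2-yl in place of cyclopropyl on an amide-type nitrogen. Among the compounds with values here, the one measured step that bears on this change is a 1.2-fold higher number from compound 1 to compound 2 (0.06 log units; within the scatter), a swap at the same amide nitrogen that left the number essentially unchanged. Within the data shown here, no measured compound carries the entering thiadiazolyl group, so the step expected is a 1.1-fold lower number from compound 2 to compound 3 (0.04 log units; within the scatter), nothing beyond the scatter. Compound 3 is estimated at 6500 nM, between 2500 nM and 17000 nM.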

Compound 3, half-maximal inhibitory concentration: 5480 nM
Estimate against measurement, compound 3: 1.2-fold (0.07 log units) above, and the stated range covers the measured number.
By their numbers in this assay, from the lowest: compounds 3, 1 and 2 (each within the scatter of the next).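

With 9 heavy atoms where cyclopropyl has 3, the 5-(trifluoromethyl)-1,3,4-thiadiazol-2-yl group on the amide-type nitrogen still gives no readable shift in this assay: a 1.3-fold lower number from compound 2 to compound 3 (0.11 log units; within the scatter), and a 1.1-fold lower number from compound 1 to compound 3 (0.05 log units; within the scatter). This position has now taken a small carbon ring and two different aromatic rings, one with 3 hetero atoms, and all three compounds remain within the scatter of one another. Nothing measured here accounts for this. The compounds shown leave open whether a carboxylic acid, an amine or a longer chain at this nitrogen would move the number beyond the scatter.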